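The compounds below may be only part of what the source reports. "The series", "measured", "known", "first", "only" and "open" are said of these compounds alone.

Measured so far in an assay on isolated protein for binding affinity to melatonin receptor type 1A (Homo sapiens); a higher number here means a weaker inhibitor, a lower number a stronger inhibitor:
compound 1 `COc1cccc(Oc2ccc(NC(=O)C3CC3)cc2)c1`, 99 nM
compound 2 `CCCC(=O)Nc1ccc(Sc2cccc(OC)c2)cc1`, 29 nM
compound 3 `CCCC(=O)Nc1ccc(Nc2cccc(OC)c2)cc1`, 31 nM

Compound 3 stands second highest of the three numbers. Its nearest neighbour is compound 2, whose number lies within the scatter of its own, so no order can be read between those two. Compound 1 lies furthest away, with a number beyond the scatter higher than that of compound 3. Compound 4 `COc1cccc(Nc2ccc(NC(=O)C3CC3)cc2)c1` has not been measured; it differs from compound 3 by cyclopropyl in place of propyl on a carbonyl carbon. Among the compounds with values here, no measured pair shows this change on its own, since compound 1 differs from the other two in another part of the molecule as well. The step is therefore expected to be small, at most a modest rise in the number and possibly within the scatter: a 1.5-fold higher number from compound 3 to compound 4 (0.16 log units; within the scatter). Compound 4 is accordingly expected to give 45 nM in this assay, with a range from 15 nM to 130 nM.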

Compound 4, inhibition constant: 61 nM
The estimate for compound 4 lay 1.4-fold (0.13 log units) below the measured number; low and high end bracket the measured number.
By their numbers in this assay, from the lowest: compounds 2, 3, 4 and 1 (each within the scatter of the next, the first and the last beyond it).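

In this assay, within the data shown here, cyclopropyl in place of propyl on a carbonyl carbon gives a 2.0-fold higher number from compound 3 to compound 4 (0.29 log units; within the scatter) and is the first single change at this position that can be read. It shows that a ring of three carbons can replace the open propyl chain of the same heavy-atom count without a shift that stands clear of the scatter. Nothing given here bears on the reason for the size of this step. As far as these compounds go, whether a longer chain, a phenyl ring or an amine on this carbonyl carbon would hold the number in this range remains open.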